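Amino for Chloro Carried onto a Second Core

The compounds below may be only part of what the source reports. "The series", "measured", "known", "first", "only" and "open" are said of these compounds alone.

Measured so far:
compound 1, `Fc1cccc(F)c1C#Cc1ccc2nccc(Cl)c2c1`, 89.7%
compound 2, `Nc1ccnc2ccc(C#Cc3c(F)cccc3F)cc12`, 93.9%
compound 3, `Fc1cccc(F)c1C#Cc1cnc(Cl)c2ccccc12`, 94%

All three were tested in a functional assay on LS174T cells (Homo sapiens) for inhibition, with a stated time of 4 days, tested at 10 uM; a higher number here means a stronger effect of the compound at the concentration tested, a lower number a weaker effect. Compound 1 and compound 3 are built from the same atoms joined differently; the difference between the two cores is not broken down here. Compound 2 arises from compound 1 by amino in place of chloro on an aromatic carbon, and that change gave a number 4.2 percentage points higher from compound 1 to compound 2 (within the scatter). Compound 4, `Nc1ncc(C#Cc2c(F)cccc2F)c2ccccc12`, is not yet measured. It arises from compound 3 by amino in place of chloro on an aromatic carbon. This is the same kind of change, though the place differs: in compound 1 it sits opposite the ring nitrogen, in compound 3 next to the ring nitrogen and para to a large group. Because compound 3 already gives 94% and the earlier step of a number 4.2 percentage points higher from compound 1 to compound 2 (within the scatter) stayed within the scatter, the expected step is a number 1 percentage points higher from compound 3 to compound 4 (within the scatter). Compound 4 is therefore estimated at 95%.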

Compound 4, a percentage reported as inhibition, at one concentration (the size of the read-out at that concentration, not a potency): 93.1%
The estimate for compound 4 lay 1.9 percentage points above the measured number; measured number inside the range.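

In this assay, amino in place of chloro on an aromatic carbon gave a number 0.9 percentage points lower from compound 3 to compound 4 (within the scatter), and the step on this core cannot be told apart from the step on the first core: the same change on two cores in this assay, a number 4.2 percentage points higher (within the scatter) from compound 1 to compound 2 and a number 0.9 percentage points lower (within the scatter) from compound 3 to compound 4, 5.1 percentage points apart, within the scatter of two such steps. Within this assay, the swap therefore shows no sign of depending on which of the two cores carries it. This does not show that amino and chloro are equivalent, since a read-out at one concentration is not a potency and steps this small could hide a real difference.

The compounds shown leave open how either core would respond to other groups at this place, such as a methoxy group or a dimethylamino group. They also leave open how amino and chloro compare at lower concentrations.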